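Swapping trifluoromethyl for methoxycarbonyl on the thiazole amide

The compounds below may be only part of what the source reports. "The series", "measured", "known", "first", "only" and "open" are said of these compounds alone.

Measured compounds:
compound 1, `CC(C)[C@H](C(=O)Nc1ccon1)c1ccc(Cl)cc1`, 90%
compound 2, `CC(C)C(C(=O)Nc1nc2ccccc2s1)c1ccc(Cl)cc1`, 91%
compound 3, `CC(C)[C@H](C(=O)Nc1ncc(C(F)(F)F)s1)c1ccc(Cl)cc1`, 95%

The three compounds share a common core, an amide built from a branched acid bearing a chlorophenyl group, joined to different five-membered aromatic rings. In a functional assay on CHO cells for agonist activity at Free fatty acid receptor 2 (Homo sapiens), read by cAMP accumulation (a lower number here means a smaller maximal response, a higher number a larger maximal response), compound 1 gives 90%, compound 2 gives 91%, and compound 3 gives 95%. Compound 3 carries numerically the highest of the three numbers, but its gap to compound 2 and its gap to compound 1 both lie within the usual scatter, so no ranking among them can be drawn; all three reach close to the full response of the reference.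

Compound 4, `COC(=O)c1cnc(NC(=O)[C@H](c2ccc(Cl)cc2)C(C)C)s1`, has not yet been tested. It differs from compound 3 in one place: methoxycarbonyl in place of trifluoromethyl on an aromatic carbon.

Among the compounds with values here, no measured pair in this set shows what such a swap does. With all three measured compounds already giving near-maximal responses, the expectation is that compound 4 stays in the same region, and the step of a number 7 percentage points lower from compound 3 to compound 4 (within the scatter) in this assay is expected to be small, with no direction beyond the scatter. Compound 4 is estimated to give 88%, with a range from 70% to 100%.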

Compound 4, largest response reached (reported as efficacy), in percent of the reference or control that the assay uses: 98%
For compound 4 the middle estimate is 10 percentage points below the measured one; the range from low to high includes it.
By their numbers in this assay, from the lowest: compounds 1, 2, 3 and 4 (each within the scatter of the next).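

In this assay, replacing trifluoromethyl with methoxycarbonyl gives a number 3 percentage points higher from compound 3 to compound 4 (within the scatter), so this aromatic carbon next to the ring sulfur can carry either group without a change in maximal response that stands out from the scatter. The two groups have the same number of heavy atoms but differ in make-up: methoxycarbonyl brings oxygen, a double bond outside the aromatic ring and two hydrogen-bond acceptors, whereas trifluoromethyl has fluorine and no acceptors, and these differences leave no mark on this read-out. Nothing available here explains why the two compounds read alike.

The compounds shown leave open how far this tolerance extends, for example whether a carboxylic acid, an amine or a longer chain on the same carbon would still give a response close to that of compound 3 and compound 4. The read-out also reports only the largest response reached, so it cannot tell whether the swap alters the amount of compound needed to reach that response.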